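Replacing a Nine-Carbon Chain with a Dimethylaminophenyl Group

The source may hold more compounds than are shown below. What is called first, only, known or untested is meant among the compounds shown, and "the series" means these compounds.

Two compounds built on a shared core have been examined in an assay on isolated protein for inhibition of Maltase-glucoamylase (Homo sapiens), tested at 100 uM; a higher number here means more inhibition at the concentration tested (going by the name of the read-out), a lower number less inhibition. Compound 1 `C=C1CC[C@@H]2[C@](C)(CO)[C@H](O)CC[C@@]2(C)[C@@H]1/C=C/C1=C/C(=C/c2ccco2)OC1=O`, which carries a furan-bearing side arm and two free hydroxyl groups, gives 49.6% in this assay. Compound 2 `C=C1CC[C@@H]2[C@](C)(COC(=O)c3cccnc3)[C@H](OC(=O)c3cccnc3)CC[C@@]2(C)[C@@H]1/C=C/C1=C/C(=C\C(C)=C\CCC/C=C/C)OC1=O`, in which both hydroxyls are esterified with pyridinecarboxylic acid and the side arm ends in a branched, unsaturated chain, gives 68.9%. Compound 2 therefore stands highest of the two numbers, and its gap to compound 1 lies beyond the usual scatter of the measurement.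

Compound 3 `C=C1CC[C@@H]2[C@](C)(COC(=O)c3cccnc3)[C@H](OC(=O)c3cccnc3)CC[C@@]2(C)[C@@H]1/C=C/C1=C/C(=C\c2ccc(N(C)C)cc2)OC1=O` has not yet been measured. It keeps the two esters of compound 2 but differs in one place: a group of 9 heavy atoms (8 carbon, 1 nitrogen; one six-membered aromatic ring of carbon only) in place of a group of 9 heavy atoms (9 carbon; no ring), on a double-bonded chain carbon bound to a double-bonded ring carbon. Within the data shown here, no measured pair isolates this exchange, so the size of its effect cannot be read from the numbers at hand. Among the measured compounds shown here, because compound 1, the only other compound with a ring at this position, gives 49.6%, a step downward in this assay is expected, of modest size, from compound 2 to compound 3 a number 13.9 percentage points lower from compound 2 to compound 3 (beyond the scatter). The estimate for compound 3 is 55%, with a range from 35% to 75%.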

Compound 3, a percentage reported as inhibition, at one concentration (the size of the read-out at that concentration, not a potency): 74.8%
Beside the measured number, compound 3's estimate is 19.8 percentage points below it, within the range that was stated.
By their numbers in this assay, from the lowest: compound 1; then compounds 2 and 3 (each within the scatter of the next).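

The exchange of the open chain for 4-(dimethylamino)phenyl, on a double-bonded chain carbon bound to a double-bonded ring carbon, gives a number 5.9 percentage points higher from compound 2 to compound 3 (within the scatter) in this assay. With both pyridinecarboxylic esters in place, this position therefore accepts either an unsaturated open chain with no ring or a six-membered aromatic ring of carbon only, with no difference that can be told from the scatter, and the hydrogen-bond acceptor that enters with the new group brings no separable change in the read-out. No measurement shown offers a reason for this outcome, so the result stands as an observation only.

The compounds shown leave open whether the same exchange would hold with free hydroxyl groups in place of the esters, since compound 1 differs from compound 3 in more than one place and the two cannot be read against each other. They also leave open how an unsubstituted phenyl, a phenyl carrying a carboxylic acid or a primary amine, or a shorter chain would read at this position, and how compound 2 and compound 3 would stand as potencies rather than at a single concentration.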